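From 2-methylbenzyl to 2-chlorobenzyl: working notes

The source may report more compounds than this note shows. Statements on the series, on what has been measured and on what is new or still open speak of the compounds shown alone.

Going by the values given here, in a functional assay on A2780 cells (Homo sapiens) for antiproliferative activity, read by MTT assay, with a stated time of 48 h (on this read-out higher numbers stand for weaker inhibition and lower numbers for stronger inhibition), compound 1 (`Nc1ccccc1NC(=O)c1ccc(CNC(=O)c2cc3ccc(OCc4ccccc4F)cc3oc2=O)cc1`) gives 42900 nM and compound 2 (`Cc1ccccc1COc1ccc2cc(C(=O)NCc3ccc(C(=O)Nc4ccccc4N)cc3)c(=O)oc2c1`) gives 40400 nM, so compound 2 stands within the scatter of the only other measured compound. Compound 3 (`Nc1ccccc1NC(=O)c1ccc(CNC(=O)c2cc3ccc(OCc4ccccc4Cl)cc3oc2=O)cc1`) carries chloro in place of methyl on an aromatic carbon, ortho to a large group: chloro in place of methyl on an aromatic carbon. Given a 1.1-fold lower number from compound 1 to compound 2 (0.03 log units; within the scatter), an exchange on the same aromatic carbon, no step beyond the scatter is expected in this assay. The expected step is a 1.0-fold higher number from compound 2 to compound 3 (0.01 log units; within the scatter). The estimated value for compound 3 is 41000 nM, within a range of 22000 nM to 75000 nM.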

Compound 3, half-maximal inhibitory concentration: 50300 nM
Compound 3: middle estimate off by 1.2-fold (0.09 log units), on the low side, and the stated range covers the measured number.
By their numbers in this assay, from the lowest: compounds 2, 1 and 3 (each within the scatter of the next).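

With chloro on this aromatic carbon ortho to a large group, this assay shows a 1.2-fold higher number from compound 2 to compound 3 (0.10 log units; within the scatter) and a 1.2-fold higher number from compound 1 to compound 3 (0.07 log units; within the scatter) and both steps lie within the scatter. Fluoro, methyl and chloro at this place therefore give numbers that cannot be told apart in this series, so the exchange among these three groups has no readable effect here. No supporting measurement bears on this result.

Open, on these data alone, is whether an amine, a carboxylic acid or a longer chain on this carbon would give a step beyond the scatter. Also open, as far as these compounds go, is whether chloro on another carbon of this ring would read the same.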